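Swapping a pyridine for cyclopropyl on the shared core

This account rests on a few compounds, and the source may have more. Where it says the series, first, only, none or still open, it means among the compounds named here.

Within the data shown here, compound 2 `CC(C)n1nc(-c2cc(-c3ccccn3)on2)c(C(N)=O)c1N` is one of two compounds measured in an assay on isolated protein for inhibition of proto-oncogene tyrosine-protein kinase receptor Ret (Homo sapiens), read by radiometric assay and 33P incorporation, in the presence of a further agent that is not named here (on this read-out lower numbers stand for stronger inhibition and higher numbers for weaker inhibition), where compound 2 gives 4800 nM. Its neighbour, compound 1 `CC(C)n1nc(-c2cc(-c3cccnc3)on2)c(C(N)=O)c1N`, gives 3400 nM in this assay; a 1.4-fold higher number from compound 1 to compound 2 (0.15 log units; within the scatter). Compound 3 `CC(C)n1nc(-c2cc(C3CC3)on2)c(C(N)=O)c1N` carries cyclopropyl in place of pyridin-2-yl on an aromatic carbon. Among the measured compounds shown here, no measured step exchanges an aromatic ring for a small carbon ring, so none bears directly on this change; the only step seen is a 1.4-fold higher number from compound 1 to compound 2 (0.15 log units; within the scatter). The expectation for compound 3 is therefore a 1.1-fold higher number from compound 2 to compound 3 (0.06 log units; within the scatter), a move not beyond the scatter. Compound 3 is estimated at 5500 nM, within a range from 2000 nM to 15000 nM.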

Compound 3, half-maximal inhibitory concentration: 44 nM
Estimate against measurement, compound 3: 130-fold (2.10 log units) above; measured number below the stated range.
By their numbers in this assay, from the lowest: compound 3; then compounds 1 and 2 (each within the scatter of the next).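

At this position on the shared core, the choice of group matters far more than the swap between the two pyridines suggested. In this assay, cyclopropyl in place of pyridin-2-yl gives a large drop in the number (a 110-fold lower number from compound 2 to compound 3 (2.04 log units; beyond the scatter)), and cyclopropyl in place of pyridin-3-yl gives a similarly large one (a 77-fold lower number from compound 1 to compound 3 (1.89 log units; beyond the scatter)). No measurement shown gives a reason for this gain. The compounds shown leave open whether the smaller group or the missing ring nitrogen counts, and how a phenyl, cyclobutyl or methyl group would read at this place.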